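Swapping 4-methoxyphenyl for 2-methoxyphenyl: a small step expected

This account rests on a few compounds, and the source may have more. Where it says the series, first, only, none or still open, it means among the compounds named here.

- compound 1 `O=C(Nc1ccccc1)C1CCN(C/C=C/c2ccccc2)CC1`: 90900 nM
- compound 2 `COc1ccc(NC(=O)C2CCN(C/C=C/c3ccccc3)CC2)cc1`: 88800 nM

Both values come from a functional assay on HepG2 cells (Homo sapiens) for inhibition, read by MTT assay, with a stated time of 72 h; a higher number here means a weaker inhibitor, a lower number a stronger inhibitor. Compound 2 stands level with compound 1, as the two lie within the scatter of each other. Compound 3 `COc1ccccc1NC(=O)C1CCN(C/C=C/c2ccccc2)CC1` carries 2-methoxyphenyl in place of 4-methoxyphenyl on an amide-type nitrogen. Among the compounds with values here, only one measured step bears on this, a 1.0-fold lower number from compound 1 to compound 2 (0.01 log units; within the scatter), and it stays within the scatter. It does not test the 2-methoxyphenyl group directly, but nothing measured points to a larger step, so none beyond the scatter is expected in this assay. The expected result is a 1.0-fold lower number from compound 2 to compound 3 (0.02 log units; within the scatter). Compound 3 is estimated at 85000 nM, with an expected range of 40000 nM to 160000 nM.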

Compound 3, half-maximal inhibitory concentration: 91200 nM
For compound 3 the middle estimate is 1.1-fold (0.03 log units) below the measured one; low and high end bracket the measured number.
By their numbers in this assay, from the lowest: compounds 2, 1 and 3 (each within the scatter of the next).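

Placing 2-methoxyphenyl in place of 4-methoxyphenyl on the amide-type nitrogen gives a 1.0-fold higher number from compound 2 to compound 3 (0.01 log units; within the scatter), and methoxy in place of hydrogen on the aromatic carbon gives a 1.0-fold higher number from compound 1 to compound 3 (0.00 log units; within the scatter). In this assay, then, compounds 1, 2 and 3 cannot be told apart, whether the methoxy is absent or present in either of these two forms. No further information is available to explain this result. Still open, as far as these compounds go, is whether a different group on this aromatic ring, such as an amine, a carboxylic acid or trifluoromethyl, would give a step beyond the scatter.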